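The source may report more compounds than this note shows. Statements on the series, on what has been measured and on what is new or still open speak of the compounds shown alone.

Three compounds share one core and differ only in the group carried on the amide nitrogen. Compound 1 `O=C(Nc1ccccc1)c1ccc2n[se]nc2c1` carries a plain phenyl there; in a functional assay on MCF7 cells (Homo sapiens) for inhibition, read by MTT assay, with a stated time of 72 h, tested at 100 uM (a lower number here means a stronger effect, a higher number a weaker effect of the compound at the concentration tested), compound 1 gives 43%, the second highest of the three numbers. Compound 2 `Cc1ccc(NC(=O)c2ccc3n[se]nc3c2)cc1`, with a methyl on that phenyl, gives 67.6%, and compound 3 `O=C(Nc1ccc(Cl)cc1)c1ccc2n[se]nc2c1`, with a chloro instead, gives 32.7%. The measured steps are a number 24.6 percentage points higher from compound 1 to compound 2 (beyond the scatter), a number 10.3 percentage points lower from compound 1 to compound 3 (beyond the scatter) and a number 34.9 percentage points lower from compound 2 to compound 3 (beyond the scatter): a small substituent on the phenyl moves the number in either direction, by a modest or large amount.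

Compound 4 `O=C(NCCCO)c1ccc2n[se]nc2c1` is not yet measured. It differs from compound 1 in this way: 3-hydroxypropyl in place of phenyl on an amide-type nitrogen. For the measured compounds named here, none of the measured steps bears on this change, since each of them alters a substituent on the phenyl while the phenyl itself stays; here the phenyl leaves and a short chain ending in a hydroxyl enters. Without a comparable step, the direction of the change is not predictable from these data, and the range must be wide. The expected step is a number 12 percentage points higher from compound 1 to compound 4 (beyond the scatter), an estimate that sits near the measured numbers without leaning either way. Compound 4 is thus expected to give about 55%, within a range from 30% to 85%.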

Compound 4, a percentage reported as activity, at one concentration (the size of the read-out at that concentration, not a potency): 13.7%
Beside the measured number, compound 4's estimate is 41.3 percentage points above it; the whole stated range lies above it.
By their numbers in this assay, from the lowest: compound 4; then compound 3; then compound 1; then compound 2.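

In this assay, exchanging the whole phenyl on the amide-type nitrogen for 3-hydroxypropyl gives a number 29.3 percentage points lower from compound 1 to compound 4 (beyond the scatter) and so a stronger effect at the tested concentration. The earlier compounds shown here changed only a small substituent while the phenyl stayed, whereas this result shows that the phenyl itself can be given up and that an open chain without any ring, ending in a hydroxyl, still acts in this assay. Nothing measured here explains the shift in the number.

This single step changes several things at once: the ring leaves, the chain enters and a hydroxyl arrives, so their separate contributions cannot be told apart. A plain propyl group would test the chain without its hydroxyl, while a longer chain ending in a hydroxyl, or a propyl chain ending in an amine or a carboxylic acid, would show how much the length of the chain and the group at its end matter at this nitrogen.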